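This account rests on a few compounds, and the source may have more. Where it says the series, first, only, none or still open, it means among the compounds named here.

Compound 1 `Nc1ccc(-c2cc(=O)c3c(N)c(Cl)cc(Cl)c3o2)cc1`: 53 nM
Compound 2 `Nc1c(F)cc(-c2cc(=O)c3c(N)c(F)cc(F)c3o2)cc1F`: 4 nM
Compound 3 `Nc1ccc(-c2cc(=O)c3c(N)c(F)ccc3o2)cc1`: 4.4 nM

These values come from a functional assay on MCF7 cells (Homo sapiens) for inhibition, in the absence of a further agent; a lower number here means a stronger inhibitor, a higher number a weaker inhibitor. Compound 3 stands level with compound 2, the two values lying within the scatter of each other. Compound 1 lies well above compound 3, beyond the scatter, and is thus the weaker inhibitor of that pair.

Compound 4 `Nc1ccc(-c2cc(=O)c3c(N)c(Cl)ccc3o2)cc1`, not yet measured, differs from compound 3 in one place: chloro in place of fluoro on an aromatic carbon. This puts chloro in place of fluoro on an aromatic carbon, ortho to an amino group. For the measured compounds named here, no measured pair isolates this exchange, so the expectation rests on indirect evidence. Going by the values given here, compound 1, the only measured compound with chloro on the shared core, gives 53 nM, although it also differs from compound 4 elsewhere. A modest rise in this assay is therefore expected, towards weaker inhibition, and it may not clear the scatter. The expected change is a 2.3-fold higher number from compound 3 to compound 4 (0.36 log units; beyond the scatter). The estimated value for compound 4 is 10 nM, within an expected range of 3 nM to 40 nM.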

Compound 4, half-maximal inhibitory concentration: 3.9 nM
For compound 4 the middle estimate is 2.6-fold (0.41 log units) above the measured one; the range from low to high includes it.
By their numbers in this assay, from the lowest: compounds 4, 2 and 3 (each within the scatter of the next); then compound 1.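

Swapping fluoro for chloro on this aromatic carbon, ortho to an amino group, is now isolated for the first time, and in this assay it gives a 1.1-fold lower number from compound 3 to compound 4 (0.05 log units; within the scatter) with no separation between the two halogens. Chloro at this position therefore does not by itself carry the weakness of compound 1, since with that chloro kept, hydrogen in place of the other chloro gives a 14-fold lower number from compound 1 to compound 4 (1.13 log units; beyond the scatter) in this assay and shows that a single change elsewhere on the ring can shift the number widely. No evidence on the cause of either step is available here.

As far as these compounds go, whether hydrogen, methyl or methoxy at this position would stay level with fluoro and chloro remains open. So does the effect of replacing the amino group on the shared core with a hydroxyl group.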